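From Acid to Amide: Expecting a Partial Recovery

A few compounds are considered here, and "the series" means these few. Any claim that something is new, unique, unknown or untested is made for them only; others in the source may bear on it.

Of the compounds shown here, three have been measured in an assay on COS-7 cells for inhibition of patatin-like phospholipase domain-containing protein 2 (Mus musculus), tested at 200 uM; a lower number here means less inhibition, a higher number more inhibition at the concentration tested (going by the name of the read-out). Compound 1 `CCOC(=O)c1cccc(-c2ccc(CN3CCN(C)CC3)o2)c1` gives 67%, and compound 2 `CCOc1ccc(-c2cccc(S(=O)(=O)N(C)C)c2)cc1` gives 63%. Compound 3 `CCOc1ccc(-c2cccc(C(=O)O)c2)cc1` stands lowest of the three with 23%. Among the compounds with values here, the one measured step of a single change, a number 40 percentage points lower from compound 2 to compound 3 (beyond the scatter), shows that arriving at the carboxy group went with a large drop. Compound 4 `CCNC(=O)c1cccc(-c2ccc(OCC)cc2)c1` differs from compound 3 by ethylamino in place of hydroxy on a carbonyl carbon; read one bond further out, carboxy becomes ethylcarbamoyl. Within the data shown here, no measured step covers this exact change, but since the carboxy group accompanied the low number of compound 3 23%, replacing it is expected to bring a rise, a number 27 percentage points higher from compound 3 to compound 4 (beyond the scatter), with wide uncertainty. Compound 4 is therefore estimated at 50%, between 25% and 75%.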

Compound 4, a percentage reported as inhibition, at one concentration (the size of the read-out at that concentration, not a potency): 62%
The estimate for compound 4 lay 12 percentage points below the measured number; the range from low to high includes it.
By their numbers in this assay, from the lowest: compound 3; then compounds 4, 2 and 1 (each within the scatter of the next).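

Replacing hydroxy with ethylamino on the carbonyl carbon reverses the loss seen with the carboxy group in this assay, giving a number 39 percentage points higher from compound 3 to compound 4 (beyond the scatter). Ethylcarbamoyl and dimethylsulfamoyl on this aromatic carbon cannot be told apart, with a number 1 percentage points lower from compound 2 to compound 4 (within the scatter), so among these three groups only carboxy goes with the low number. Nothing available explains the rise. As far as these compounds go, whether the ethyl chain itself matters stays open: a plain amino group, methylamino or a longer propylamino chain on the same carbonyl carbon would show how much of the amide substituent is needed.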